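Methyl on the Amino Nitrogen: From Compound 2 to Compound 3

This account rests on a few compounds, and the source may have more. Where it says the series, first, only, none or still open, it means among the compounds named here.

Compound 1, `Cn1ccc2cc(C#Cc3c(F)cccc3F)ccc21`: 3%
Compound 2, `Nc1ncc(C#Cc2c(F)cccc2F)c2ccccc12`: 35.5%

Of the compounds shown here, two have been measured in a functional assay on LS174T cells (Homo sapiens) for inhibition, with a stated time of 4 days, tested at 100 nM; a lower number here means a weaker effect, a higher number a stronger effect of the compound at the concentration tested. Compound 1 gives 3%, while compound 2 gives 35.5%. Compound 2 therefore stands highest of the two numbers, and its gap to compound 1 is beyond the usual scatter. Within the data shown here, the two compounds differ in more than one place, so no single step between them is known.

Compound 3, `CNc1ncc(C#Cc2c(F)cccc2F)c2ccccc12`, has not yet been measured. Relative to compound 2 the change is methyl in place of hydrogen on a nitrogen on an aromatic ring, which, seen one bond further out, turns an amino group into a methylamino group. Among the measured compounds shown here, nothing among the measured compounds shows what such a change does here. The step of a number 3.5 percentage points lower from compound 2 to compound 3 (within the scatter) is expected to be small, within the scatter. Compound 3 is accordingly estimated at 32%, with a range from 10% to 60%.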

Compound 3, a percentage reported as inhibition, at one concentration (the size of the read-out at that concentration, not a potency): 99.5%
The estimate for compound 3 lay 67.5 percentage points below the measured number; measured number above the stated range.
By their numbers in this assay, from the lowest: compound 1; then compound 2; then compound 3.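

The nitrogen on the aromatic ring turns out to be a highly sensitive place: in this assay, replacing one hydrogen with methyl, which turns the amino group into a methylamino group, gives a number 64 percentage points higher from compound 2 to compound 3 (beyond the scatter). This is the first change in a single place among these compounds, and it shows that even a group as small as methyl can shift this read-out well beyond the scatter. No measurement here explains why the step is so large.

As far as these compounds go, it remains open whether a longer chain such as ethyl, or a second methyl giving a dimethylamino group, on the same nitrogen would keep this effect. The read-out also comes from a single concentration, so it gives no potency for compound 3 and does not show how the effect changes at lower concentrations.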